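Shrinking the Ring on the Ether of Compound 2

The source may report more compounds than this note shows. Statements on the series, on what has been measured and on what is new or still open speak of the compounds shown alone.

Compound 2 `Nc1ccc2cccc(OCC3CCCC3)c2n1` is one of three compounds that share the same core and differ only in the ether group. In an assay on cells with melanin-concentrating hormone receptor 1 (Homo sapiens) as the target, read by radioligand binding (on this read-out higher numbers stand for weaker inhibition and lower numbers for stronger inhibition), compound 2 gives 53 nM. Compound 1 `CC1CCCCC1Oc1cccc2ccc(N)nc12` gives 32 nM, a number within the usual scatter of that of compound 2, so the two cannot be ranked. Compound 3 `CC1CCCC(Oc2cccc3ccc(N)nc23)C1` gives 640 nM, the highest of the three, which leaves compound 2 second highest. Compound 4 `Nc1ccc2cccc(OCC3CC3)c2n1` is not yet measured; it differs from compound 2 by cyclopropyl in place of cyclopentyl on a saturated chain carbon bound to an oxygen on an aromatic ring. Among the compounds with values here, no measured pair shows this exact change, so the expectation rests on the spread already seen. A modest weakening is expected, the step of a 2.3-fold higher number from compound 2 to compound 4 (0.35 log units; beyond the scatter) staying near the scatter. Compound 4 is estimated at 120 nM, within 35 nM to 450 nM.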

Compound 4, half-maximal inhibitory concentration: > 2000 nM
Compound 4: a limit, no number; the forecaster's own chance of this, stated with the estimate: 3%; middle value at least 16-fold (1.22 log units) from the limit.
By their numbers in this assay, from the lowest: compounds 1 and 2 (each within the scatter of the next); then compound 3. At a limit, above all of these: compound 4.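

Within the data shown here, this is the first single change read at this place, and it shows that the size of the ring on the ether matters a great deal: cyclopropyl in place of cyclopentyl gives an at least 37-fold higher number from compound 2 to compound 4 (1.57 log units; beyond the scatter). So a smaller ring here can cost far more than the closeness of compound 1 and compound 2 would hint. Compound 4 gives a limit, not a number: the limit of > 2000 nM in this assay, at which 1 of the 4 values shown sits.

Going by these compounds, whether cyclobutyl or cyclohexyl on the same chain carbon would keep the value of compound 2 stays open. So does the effect of an amine or a longer chain there.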